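The compounds below may be only part of what the source reports. "The series", "measured", "known", "first", "only" and "open" are said of these compounds alone.

Compound 1 `CCNC(=O)c1nc(-c2cc(OC)c(OC)c(OC)c2)n(-c2ccc(OC)cc2)n1` is the reference point here. Among the measured compounds shown here, in a functional assay on the whole organism for inhibition, with Rattus norvegicus as the target, read by paw edema, with stated times of 30 min and 3 h, at a dose of 0.28 mmol/kg by the oral route (a higher number here means more inhibition at the dose given (going by the name of the read-out), a lower number less inhibition), compound 1 gives 88%, the higher of the two numbers measured so far. Compound 2 `COc1ccc(-n2nc(C(=O)Nc3ccc(C)cc3)nc2-c2cc(OC)c(OC)c(OC)c2)cc1` shares the whole core and differs only in the group on the amide-type nitrogen; in this assay compound 2 gives 77%. The step of a number 11 percentage points lower from compound 1 to compound 2 (beyond the scatter) shows that trading the ethyl for the 4-methylphenyl lowered the inhibition by a modest but real amount.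

Compound 3 `COc1ccc(-n2nc(C(=O)Nc3ccccc3)nc2-c2cc(OC)c(OC)c(OC)c2)cc1` has not yet been measured. It differs from compound 1 by phenyl in place of ethyl on an amide-type nitrogen; cut one bond further out, the change reads ethylcarbamoyl to phenylcarbamoyl. For the measured compounds named here, the one measured step that bears on it is the one from compound 1 to compound 2, which placed a 4-methylphenyl on the same nitrogen. Phenyl differs from that group only by the missing methyl, so a step of similar size, downward, is expected rather than none. Compound 3 is therefore expected to give about 80%, within a range of 68% to 90%. That corresponds to an expected step of a number 8 percentage points lower from compound 1 to compound 3 (within the scatter).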

Compound 3, a percentage reported as inhibition, in the whole organism at one dose (the size of the read-out at that dose, not a potency): 69%
Estimate against measurement, compound 3: 11 percentage points above, and the stated range covers the measured number.
By their numbers in this assay, from the lowest: compounds 3 and 2 (each within the scatter of the next); then compound 1.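

In this assay, putting phenyl in place of ethyl on the amide-type nitrogen gives a number 19 percentage points lower from compound 1 to compound 3 (beyond the scatter), so a second aromatic ring at this place also sits below the ethyl amide, and among these three compounds ethyl gives the highest number, with no compound going against that. Taking the methyl off the aromatic ring, with hydrogen in its place on that aromatic carbon, gives a number 8 percentage points lower from compound 2 to compound 3 (within the scatter), so the methyl does not measurably separate the two aromatic amides, and the gap to the ethyl amide does not depend on that methyl being present. Nothing measured here explains why the ethyl amide and the aromatic amides differ.

Still open, from the compounds shown here alone, is whether the ethyl itself matters or any small chain would do: a methyl, a longer chain such as butyl, or a cyclohexyl ring on this nitrogen could show whether the number of compound 1, at 88%, holds or falls. Going by these compounds, it is also open whether an aromatic ring carrying something other than methyl, such as a carboxylic acid or an amine, would behave like the plain phenyl.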